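The compounds below may be only part of what the source reports. "The series", "measured", "known", "first", "only" and "open" are said of these compounds alone.

Among the measured compounds shown here, in an ADME assay on HepG2 cells (Homo sapiens) for cytotoxicity, read by MTT assay (a lower number here means a stronger inhibitor, a higher number a weaker inhibitor), none of the three compounds tested so far has given a number. Compound 1 `O=C(NCc1ccccc1)Oc1ccc(Cl)cc1C(=O)Nc1ccc(F)cc1` reads > 125000 nM, which is a limit of the assay. Compound 2 `O=C(NCc1ccccc1)Oc1ccc(Cl)cc1C(=O)Nc1ccc(Cl)cc1` reads > 250000 nM, and this too is a limit, so its standing can be told only as a limit, as can that of the other two compounds. Compound 3 `O=C(Nc1ccccc1)Oc1ccc(Cl)cc1`, which also carries phenyl on an amide-type nitrogen, reads > 125000 nM, again a limit.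

Compound 4 `O=C(Nc1ccccc1)Oc1ccc(Cl)cc1C(=O)Nc1ccc(Cl)cc1` departs from compound 2 by one change, phenyl in place of benzyl on an amide-type nitrogen. For the measured compounds named here, the only measured step between close relatives is a step that the two limits leave unreadable from compound 1 to compound 2. Going by the values given here, that step lies elsewhere in the structure and offers no size to carry over, and no measured step covers the change from benzyl to phenyl. The evidence is therefore thin, and no step beyond the scatter is expected in this assay, in either direction. The estimated step is a number no higher from compound 2 to compound 4 (the limit leaves the size open). The assay may well report only a limit again. For compound 4 the expected value is 250000 nM, with an estimated range from 100000 nM to 500000 nM.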

Compound 4, half-maximal inhibitory concentration: > 250000 nM
Compound 4: only a limit was reported; the forecaster's own chance of this, stated with the estimate: 75%; the middle value sits exactly at the limit.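

Compound 2 and compound 4 both give only a limit of the assay in this assay, and the step between them, phenyl in place of benzyl on an amide-type nitrogen, cannot be read. The compounds shown leave open what actual number any of them would give in this assay, since all four stand at limits.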